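Hydroxamic Acid Cinnamamides: Cytotoxicity and a Phenoxy Exchange

A few compounds are considered here, and "the series" means these few. Any claim that something is new, unique, unknown or untested is made for them only; others in the source may bear on it.

Measured compounds:
compound 1 `O=C(/C=C/c1ccccc1OCCOc1ccccc1)NO`, 45000 nM
compound 2 `O=C(/C=C/c1ccccc1OCCc1ccccc1)NO`, 83000 nM
compound 3 `O=C(/C=C/c1cccc(OCCc2ccccc2)c1)NO`, 12000 nM

Three hydroxamic acids have been tested in an ADME assay on Huh-7 cells (Homo sapiens) for cytotoxicity, read by MTT assay, with a stated time of 3 days; on this read-out higher numbers stand for lower toxicity in this test and lower numbers for higher toxicity in this test. Compound 2 gives 83000 nM in this assay, and compound 1 gives 45000 nM. The two differ by a single change: phenoxy in place of phenyl on a saturated chain carbon, two bonds along the chain from an oxygen on an aromatic ring. That change carried a 1.8-fold lower number from compound 2 to compound 1 (0.27 log units; within the scatter).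

Compound 3 shares its atoms with compound 2, joined differently; the difference between the two cores is not broken down here. In this assay compound 3 gives 12000 nM, the lowest of the three numbers, beyond the scatter from both compound 1 and compound 2.

Compound 4 `O=C(/C=C/c1cccc(OCCOc2ccccc2)c1)NO` has not yet been measured in this assay. It stands to compound 3 as compound 1 stands to compound 2: phenoxy in place of phenyl on a saturated chain carbon, two bonds along the chain from an oxygen on an aromatic ring. The place lines of the two changes agree word for word, so this is the same change seen once before.

Within the data shown here, the only precedent is the step from compound 2 to compound 1, which stayed within the scatter. On that basis the account expects a step of similar size, a 1.5-fold lower number from compound 3 to compound 4 (0.18 log units; within the scatter), from compound 3 to compound 4, resting on a 1.8-fold lower number from compound 2 to compound 1 (0.27 log units; within the scatter). Compound 4 is therefore estimated at 8000 nM in this assay, with a likely range from 3000 nM to 22000 nM.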

Compound 4, half-maximal cytotoxic concentration: 6000 nM
Beside the measured number, compound 4's estimate is 1.3-fold (0.12 log units) above it; measured number inside the range.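

In this assay, putting phenoxy in place of phenyl on a saturated chain carbon, two bonds along the chain from an oxygen on an aromatic ring, gave a 2.0-fold lower number from compound 3 to compound 4 (0.30 log units; within the scatter). Set beside the earlier case, the change looks the same on both cores, and the two steps cannot be told apart: the same change on two cores in this assay, a 1.8-fold lower number (0.27 log units; within the scatter) from compound 2 to compound 1 and a 2.0-fold lower number (0.30 log units; within the scatter) from compound 3 to compound 4, 1.1-fold (0.04 log units) apart, within the scatter of two such steps

This shows that, across these two cores, the exchange carried over without a step beyond the scatter and without any visible dependence on the core, but it does not show that phenoxy truly lowers the number, since each step on its own stays within the scatter, and two cores in a single assay give no rule for the rest of the series.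

The compounds shown leave open whether a group other than phenoxy at the same place, such as an amine, a carboxylic acid or a longer chain ending in phenyl, would give a step beyond the scatter. They also leave open whether the phenoxy exchange would stay this small on a third core, and what it would do to any read-out other than this cytotoxicity measure.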